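Lengthening the ring amine substituent of compound 1

The source may report more compounds than this note shows. Statements on the series, on what has been measured and on what is new or still open speak of the compounds shown alone.

Measured compounds:
compound 1 `CN1CCc2c(sc(NC(=O)Nc3ccc(Cl)cc3)c2C(N)=O)C1` gives 4700 nM in a functional assay (strain AB) with Danio rerio as the target, read by microscopy, with a stated time of 1 h; on this read-out lower numbers stand for an effect already at smaller amounts and higher numbers for an effect only at larger amounts of compound
compound 2 `CCN1CCc2c(sc(NC(=O)Nc3ccc(Cl)cc3)c2C#N)C1` gives > 25000 nM in this assay, which is a limit of the assay and not a number

Among the measured compounds shown here, compound 1 is the only compound with a numerical value in this assay; the other entry is a limit, as the limit of > 25000 nM in this assay, at which 1 of the 2 values shown sits, shows for compound 2. For the measured compounds named here, compound 2 also differs from compound 1 in more than one place, so the two values show no single step and offer no guide to any one change. Compound 3 `COCCCN1CCc2c(sc(NC(=O)Nc3ccc(Cl)cc3)c2C(N)=O)C1` shares the core of compound 1 and differs from it by 2-methoxyethyl in place of hydrogen on a saturated chain carbon bound to an amine nitrogen in a ring; the amide of compound 1 is kept. Going by the values given here, no step between measured compounds speaks to this kind of change. The expectation is therefore a step of modest size, from compound 1 to compound 3 of a 1.4-fold higher number from compound 1 to compound 3 (0.14 log units; within the scatter), likely within the usual scatter or a little toward an effect only at larger amounts. Compound 3 is estimated at 6500 nM in this assay, with a range from 2000 nM to 20000 nM.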

Compound 3, half-maximal effective concentration: 2400 nM
Estimate against measurement, compound 3: 2.7-fold (0.43 log units) above, within the range that was stated.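

In this assay, putting 2-methoxyethyl in place of hydrogen on a saturated chain carbon bound to an amine nitrogen in a ring gives a 2.0-fold lower number from compound 1 to compound 3 (0.29 log units; within the scatter), so the two compounds cannot be ordered on this read-out. Among the compounds shown here, this is the first single step at this position, and it shows that, with the amide kept, methyl can give way to the longer 3-methoxypropyl without a difference beyond the usual scatter. Nothing given here accounts for this result.

Compound 2 gives > 25000 nM, which is a limit of the assay and not a number, and as it differs from compound 1 in more than one place, no step can be read from it. The compounds shown leave open whether a terminal amine or a carboxylic acid in place of the methoxy end of the 3-methoxypropyl, or a still longer chain, would stay within the scatter of compound 1 or move the number beyond it in this assay.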